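Series notes: oxadiazole replacement of the oxetanyl amide

The source may hold more compounds than are shown below. What is called first, only, known or untested is meant among the compounds shown, and "the series" means these compounds.

Measured so far:
compound 1 `CCN(CC)S(=O)(=O)c1ccc(S(=O)(=O)N2CCC[C@@H](C(=O)NC3CN(C(=O)C4CC4)C3)C2)cc1`: 18500 nM
compound 2 `CCN(CC)S(=O)(=O)c1ccc(S(=O)(=O)N2CCC[C@@H](C(=O)NC3CN(S(C)(=O)=O)C3)C2)cc1`: 7400 nM
compound 3 `CCN(CC)S(=O)(=O)c1ccc(S(=O)(=O)N2CCC[C@@H](C(=O)NC3COC3)C2)cc1`: 13800 nM

All three were run in a functional assay on BXPC-3 cells (Homo sapiens) for inhibition, read by MTT assay, with a stated time of 7 days; a lower number here means a stronger inhibitor, a higher number a weaker inhibitor. Compound 3 gives the second highest number of the three; its nearest neighbour is compound 1, with a 1.3-fold lower number from compound 1 to compound 3 (0.13 log units; within the scatter), and compound 2 lies a 1.9-fold higher number from compound 2 to compound 3 (0.27 log units; within the scatter) away, so the three sit within the scatter of one another apart from a 2.5-fold lower number from compound 1 to compound 2 (0.40 log units; beyond the scatter).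

Compound 4 `CCN(CC)S(=O)(=O)c1ccc(S(=O)(=O)N2CCC[C@@H](c3nc(C)no3)C2)cc1` is not yet measured. Relative to compound 3 the change is 3-methyl-1,2,4-oxadiazol-5-yl in place of (oxetan-3-yl)carbamoyl on a saturated ring carbon. For the measured compounds named here, the measured steps only swap the group on the amide-type nitrogen and all stayed near the scatter; none removes the carbamoyl itself, so no step bears directly on this change. For compound 4 a step of a 1.2-fold lower number from compound 3 to compound 4 (0.06 log units; within the scatter) is expected, essentially none beyond the scatter, with a wide range. Compound 4 is estimated at 12000 nM, between 3500 nM and 40000 nM.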

Compound 4, half-maximal inhibitory concentration: 2900 nM
Compound 4: middle estimate off by 4.1-fold (0.62 log units), on the high side, outside the stated range (below it).
By their numbers in this assay, from the lowest: compound 4; then compounds 2, 3 and 1 (each within the scatter of the next, the first and the last beyond it).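

In this assay, 3-methyl-1,2,4-oxadiazol-5-yl in place of (oxetan-3-yl)carbamoyl on the saturated ring carbon gives a 4.8-fold lower number from compound 3 to compound 4 (0.68 log units; beyond the scatter), so changing the carbamoyl itself moves the number beyond the scatter. Against the (1-(methylsulfonyl)azetidin-3-yl)carbamoyl, the same group gives a 2.6-fold lower number from compound 2 to compound 4 (0.41 log units; beyond the scatter), so the amide is not needed at this position for activity in this assay. No measurement explains these steps.

Going by these compounds, whether the step comes from the oxadiazole ring or its methyl remains open. A 3-ethyl or 3-phenyl oxadiazole, or a carboxylic acid on this carbon, would test this.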